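The source may report more compounds than this note shows. Statements on the series, on what has been measured and on what is new or still open speak of the compounds shown alone.

Two compounds share a core and differ only in the five-membered ring attached to the carbon with a double bond to nitrogen. Compound 1 `Cn1cncc1/C=N/Nc1ccnc2cc(Cl)ccc12` carries a 1-methyl-1H-imidazol-5-yl group, and in a functional assay on KB cells (Homo sapiens) for cytotoxicity (a lower number here means that less compound is needed, a higher number that more compound is needed for the effect), compound 1 gives 73.8 uM. Compound 2 `Cn1ccnc1/C=N/Nc1ccnc2cc(Cl)ccc12` carries a 1-methyl-1H-imidazol-2-yl group instead, and in this assay compound 2 gives 17.1 uM. That change gave a 4.3-fold lower number from compound 1 to compound 2 (0.64 log units; beyond the scatter), so compound 2 has the lowest number of the two. Compound 3 `Clc1ccc2c(N/N=C/c3ccc[nH]3)ccnc2c1` moves one step further: 1H-pyrrol-2-yl in place of 1-methyl-1H-imidazol-2-yl on a carbon with a double bond to nitrogen. For the measured compounds named here, the only measured step, from compound 1 to compound 2, changed where the methyl-imidazole ring is joined and says little about exchanging it for a pyrrole; no measured step bears directly on this change. The expectation for compound 3 is therefore a step of a 1.5-fold higher number from compound 2 to compound 3 (0.16 log units; within the scatter), not beyond the scatter. Compound 3 is estimated at 25 uM, in a range from 8 uM to 80 uM.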

Compound 3, concentration for half-maximal effect: 4.8 uM
For compound 3 the middle estimate is 5.2-fold (0.72 log units) above the measured one; measured number below the stated range.
By their numbers in this assay, from the lowest: compound 3; then compound 2; then compound 1.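

This result shows that the position on a carbon with a double bond to nitrogen responds to the kind of ring placed there, not only to where a methyl-imidazole ring is joined: 1H-pyrrol-2-yl in place of 1-methyl-1H-imidazol-2-yl gave a 3.6-fold lower number from compound 2 to compound 3 (0.55 log units; beyond the scatter) in this assay. Against the 1-methyl-1H-imidazol-5-yl group, the same ring gave a 15-fold lower number from compound 1 to compound 3 (1.19 log units; beyond the scatter) and this is the largest step among the three compounds. Nothing measured here ties the lower number to any one difference between these groups, such as the hydrogen-bond donor that 1H-pyrrol-2-yl brings.

The compounds shown leave open whether that ring hydrogen matters, which a 1-methyl-1H-pyrrol-2-yl group would address. They also leave open how a phenyl or furan-2-yl ring would behave on the same carbon.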